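A charged ring group on the chain of compound 3

The source may hold more compounds than are shown below. What is called first, only, known or untested is meant among the compounds shown, and "the series" means these compounds.

In a functional assay for inhibition, with Homo sapiens as the target (a lower number here means that less compound is needed, a higher number that more compound is needed for the effect), compound 1 (`CC(=O)Nc1ccc(C2=NNC(=O)CC2)cc1`) gives 1 ug/mL and compound 2 (`O=C1CCC(c2ccc(NC(=O)CCCl)cc2)=NN1`) gives 0.98 ug/mL (that is a 1.0-fold lower number from compound 1 to compound 2 (0.01 log units; within the scatter)). Compound 3 (`O=C1CCC(c2ccc(NC(=O)CCCCl)cc2)=NN1`) stands only at a limit in this assay (> 46.4 ug/mL). Both steps reaching it are large (an at least 46-fold higher number from compound 1 to compound 3 (1.66 log units; beyond the scatter) and an at least 47-fold higher number from compound 2 to compound 3 (1.67 log units; beyond the scatter)). Compound 4 (`C[N+]1(CC(=O)Nc2ccc(C3=NNC(=O)CC3)cc2)CCCC1`) replaces the 2-chloroethyl of compound 3 with a larger ring-bearing group of net charge +1 (a group of 6 heavy atoms (5 carbon, 1 nitrogen; one five-membered non-aromatic ring with 1 hetero atom) in place of a group of 3 heavy atoms (2 carbon, 1 chlorine; no ring), on a saturated chain carbon bound to a carbonyl carbon), on a saturated chain carbon bound to a carbonyl carbon. At this place compound 2 stays level with compound 1 while compound 3 does not, so the outcome is uncertain. The expected step is toward a lower number in this assay (an at least 5.8-fold lower number from compound 3 to compound 4 (0.76 log units; beyond the scatter)), though another limit remains possible. For compound 4 the estimate is 8 ug/mL (expected range 1 ug/mL to 46 ug/mL).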

Compound 4, half-maximal effective concentration: > 46.4 ug/mL
Compound 4 was reported as a limit (the forecaster's own chance of this, stated with the estimate: 35%); middle value at least 5.8-fold (0.76 log units) away from the limit.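

A second, very different group at this place, on a saturated chain carbon bound to a carbonyl carbon, also comes with a large step in this assay: an at least 46-fold higher number from compound 1 to compound 4 (1.66 log units; beyond the scatter), and an at least 47-fold higher number from compound 2 to compound 4 (1.67 log units; beyond the scatter). So the rise seen with the 2-chloroethyl is not confined to that one group. Compound 4 stands only at a limit, as compound 3 does, so the step between those two cannot be read: the limit of > 46.4 ug/mL in this assay, at which 2 of the 4 values shown sit.

As far as these compounds go, whether a dimethylamino group, which is an amine, or a hydroxyl at this place would stay level with compound 1 remains open. So does how far beyond the limit compound 3 and compound 4 truly lie.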